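A few compounds are considered here, and "the series" means these few. Any claim that something is new, unique, unknown or untested is made for them only; others in the source may bear on it.

Compound 3 `O=C(Nc1cccc(Cc2ccccc2)c1)C1CCCN(C(=O)c2cc(C(F)(F)F)cc(C(F)(F)F)c2)C1` stands level with compound 1 `O=C(Nc1cccc(Oc2ccccn2)c1)C1CCCN(C(=O)c2cc(C(F)(F)F)cc(C(F)(F)F)c2)C1` at the digits shown: in an ADME assay on PC-3 cells (Homo sapiens) for cytotoxicity, read by WST assay, tested at 100 uM (on this read-out higher numbers stand for more inhibition at the one concentration tested (going by the name of the read-out) and lower numbers for less inhibition), compound 3 gives 0%, compound 1 gives 0%, and compound 2 `O=C(Nc1cccc(-c2cnco2)c1)C1CCCN(C(=O)c2cc(C(F)(F)F)cc(C(F)(F)F)c2)C1` gives 9%. The steps of no change at the digits printed from compound 1 to compound 3 (within the scatter) and a number 9 percentage points lower from compound 2 to compound 3 (within the scatter) both stay within the scatter, so among these three compounds the substituent swaps on the aromatic carbon leave the read-out flat. Compound 4 `O=C(Nc1cccc(N2CCCC2=O)c1)C1CCCN(C(=O)c2cc(C(F)(F)F)cc(C(F)(F)F)c2)C1` differs from compound 3 in one place: 2-oxopyrrolidin-1-yl in place of benzyl on an aromatic carbon. Among the measured compounds shown here, no measured step exchanges a benzyl for a 2-oxopyrrolidin-1-yl, but the two steps that reach compound 3 were each within the scatter, so no step beyond the scatter is expected; the estimated step is a number 3 percentage points higher from compound 3 to compound 4 (within the scatter). Compound 4 is therefore expected to give about 3%, with a range from 0% to 15%.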

Compound 4, a percentage reported as inhibition, at one concentration (the size of the read-out at that concentration, not a potency): 0%
Estimate against measurement, compound 4: 3 percentage points above, within the range that was stated.
By their numbers in this assay, from the lowest: compounds 1, 3, 4 and 2 (each within the scatter of the next).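

In this assay, among the compounds shown here, 2-oxopyrrolidin-1-yl, the only one of these four groups with a non-aromatic ring, gives no change at the digits printed from compound 3 to compound 4 (within the scatter), no change at the digits printed from compound 1 to compound 4 (within the scatter) and a number 9 percentage points lower from compound 2 to compound 4 (within the scatter). The read-out at this position on the aromatic carbon thus stays flat with a five-membered non-aromatic ring as well as with the aromatic groups. No supporting data bear on this result.

As far as these compounds go, whether a primary amine or a carboxylic acid at this position would move the read-out beyond the scatter remains open. So does whether any group here would give substantial inhibition at the one concentration tested.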